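A few compounds are considered here, and "the series" means these few. Any claim that something is new, unique, unknown or untested is made for them only; others in the source may bear on it.

Compound 3 `S=C(NCc1cnc2scc(C#CC3CC3)n12)Nc1cccc(Cl)c1` gives 27.6 nM in an assay on cells for inhibition of Indoleamine 2,3-dioxygenase 1 (Homo sapiens) (a lower number here means a stronger inhibitor, a higher number a weaker inhibitor), the lowest of the three numbers measured. Compound 1 `N#Cc1ccc(NC(=O)NCc2cnc3scc(C#Cc4ccsc4)n23)cc1` gives 73.9 nM, and compound 2 `CCCCNC(=S)NCc1cnc2scc(C#CC3CC3)n12` gives 502 nM in this assay. Within the data shown here, the one single-point step measured so far runs from compound 2 to compound 3 and gives an 18-fold lower number from compound 2 to compound 3 (1.26 log units; beyond the scatter), which shows how much the group on the amide-type nitrogen can matter.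

Compound 4 `N#Cc1ccc(NC(=S)NCc2cnc3scc(C#CC4CC4)n23)cc1` differs from compound 3 by 4-cyanophenyl in place of 3-chlorophenyl on an amide-type nitrogen. Among the measured compounds shown here, no measured step swaps one aryl group for another on that nitrogen, so the direction is not fixed by the data. Compound 1, which also carries a 4-cyanophenyl there, gives 73.9 nM, but it differs from compound 4 in two further places, so it is only a loose guide. Compound 4 is therefore expected to stay close to compound 3, with a step of a 1.6-fold higher number from compound 3 to compound 4 (0.21 log units; within the scatter) and an estimated value of 45 nM, in the range 15 nM to 140 nM.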

Compound 4, half-maximal inhibitory concentration: 16.4 nM
Compound 4: middle estimate off by 2.7-fold (0.44 log units), on the high side, and the stated range covers the measured number.
By their numbers in this assay, from the lowest: compounds 4 and 3 (each within the scatter of the next); then compound 1; then compound 2.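

In this assay, exchanging one aryl group for the other on this amide-type nitrogen gives a 1.7-fold lower number from compound 3 to compound 4 (0.23 log units; within the scatter) and so leaves 3-chlorophenyl and 4-cyanophenyl indistinguishable here, even though the two groups differ in their substituent and in its place on the ring. Against butyl, 4-cyanophenyl gives a 31-fold lower number from compound 2 to compound 4 (1.49 log units; beyond the scatter) and so shows that the large gap from butyl is not confined to 3-chlorophenyl, as both aryl groups shown lie well apart from butyl in the same direction. Nothing measured here accounts for the gap between these aryl groups and butyl.

The compounds shown leave open how a saturated ring such as cyclohexyl or a benzyl group on this nitrogen compares with butyl and with the two aryl groups. They also leave open what a carbonyl in place of the thiocarbonyl does when everything else in compound 4 stays the same.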